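A Methyl Group on the Urea Nitrogen of Compound 3

This account rests on a few compounds, and the source may have more. Where it says the series, first, only, none or still open, it means among the compounds named here.

Compound 3 `N#CC1CN1C(N)=O` gives 288000 nM in a functional assay on RPMI-8226 cells (Homo sapiens) for inhibition (a lower number here means a stronger inhibitor, a higher number a weaker inhibitor), the highest of the three numbers measured. Among the compounds with values here, its nearest neighbour is compound 1 `CC(C)(C)NC(=O)N1CC1C#N`, which gives 120000 nM; the step of a 2.4-fold higher number from compound 1 to compound 3 (0.38 log units; beyond the scatter) is the only measured change at this position. Compound 2 `N#CC1CN1C(=O)Nc1ccccc1` gives 5300 nM, far from compound 3.

Compound 4 `CNC(=O)N1CC1C#N` is the next step: methyl in place of hydrogen on an amide-type nitrogen. Within the data shown here, only the step from compound 1 to compound 3 bears on it, and it shows that removing a tert-butyl group from this nitrogen raised the number modestly. A methyl group is smaller than tert-butyl, so compound 4 is expected to sit between compound 3 and compound 1, with a small shift toward lower numbers, perhaps at the edge of the scatter. The expected step of a 1.4-fold lower number from compound 3 to compound 4 (0.16 log units; within the scatter) is therefore a modest one downward. Compound 4 is estimated at 200000 nM, with a range of 90000 nM to 420000 nM.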

Compound 4, half-maximal inhibitory concentration: 26000 nM
Estimate against measurement, compound 4: 7.7-fold (0.89 log units) above, and the stated range ends above it.
By their numbers in this assay, from the lowest: compound 2; then compound 4; then compound 1; then compound 3.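

The step of an 11-fold lower number from compound 3 to compound 4 (1.04 log units; beyond the scatter) in this assay is large, so a single methyl group on this amide-type nitrogen moves the number much further than the earlier change between hydrogen and tert-butyl did. The step of a 4.6-fold lower number from compound 1 to compound 4 (0.66 log units; beyond the scatter) is also beyond the scatter, which shows that among compound 3, compound 4 and compound 1 the numbers do not move steadily from hydrogen through methyl to tert-butyl: the methyl compound has the lowest number of the three. Nothing available here accounts for this result.

The compounds shown leave open whether an ethyl group or a longer chain on this nitrogen would lie closer to compound 4 or to compound 1. They also leave open how a benzyl group would compare with the phenyl group of compound 2, which keeps the lowest number at 5300 nM in this series.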